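From hydroxy to amino on compound 3

A few compounds are considered here, and "the series" means these few. Any claim that something is new, unique, unknown or untested is made for them only; others in the source may bear on it.

- compound 1 `COc1ccc(C(=O)c2ccc(OC)c3c2C=CC(C)(C)O3)c(NC(=O)CN)c1`: 1250 nM
- compound 2 `COc1ccc(C(=O)c2ccc(OC)c3c2C=CC(C)(C)O3)c(NC(=O)CN(C)C)c1`: 6530 nM
- compound 3 `C=C(c1ccc(OC)cc1NC(=O)CO)c1ccc(OC)c2c1C=CC(C)(C)O2`: 590 nM

In a functional assay on MCF7 cells (Homo sapiens) for antiproliferative activity, read by MTT assay, with a stated time of 48 h (on this read-out higher numbers stand for weaker inhibition and lower numbers for stronger inhibition), compound 3 gives 590 nM, the lowest of the three numbers. Compound 4 `C=C(c1ccc(OC)cc1NC(=O)CN)c1ccc(OC)c2c1C=CC(C)(C)O2`, not yet measured, differs from it in one place: amino in place of hydroxy on a saturated chain carbon bound to a carbonyl carbon. In words, this is amino in place of hydroxy on a saturated chain carbon bound to a carbonyl carbon.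

Going by the values given here, no measured step makes this exchange. Among the compounds with values here, the only measured step, a 5.2-fold higher number from compound 1 to compound 2 (0.72 log units; beyond the scatter), is modest, but it puts dimethylamino in place of amino and so bears on it only loosely. Compound 1 carries the amino group and gives 1250 nM, but it also differs from compound 3 elsewhere, so that value does not isolate the exchange. In this assay, only a small move towards a higher number is therefore expected, probably no larger than the scatter. The expected change is a 1.4-fold higher number from compound 3 to compound 4 (0.13 log units; within the scatter). Compound 4 is estimated at 800 nM, with an expected range of 250 nM to 2500 nM.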

Compound 4, half-maximal inhibitory concentration: 780 nM
The estimate for compound 4 lay 1.0-fold (0.01 log units) above the measured number; low and high end bracket the measured number.
By their numbers in this assay, from the lowest: compounds 3, 4 and 1 (each within the scatter of the next, the first and the last beyond it); then compound 2.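

In this assay amino in place of hydroxy on a saturated chain carbon bound to a carbonyl carbon gives a 1.3-fold higher number from compound 3 to compound 4 (0.12 log units; within the scatter) and so compound 3 and compound 4 cannot be told apart on this read-out. The earlier step, a 5.2-fold higher number from compound 1 to compound 2 (0.72 log units; beyond the scatter), exchanged amino for dimethylamino on the core of compound 1 and did not compare amino with hydroxy, whereas this pair makes that comparison directly on the core of compound 3. Nothing available accounts for the two groups reading alike.

As far as these compounds go, whether hydroxy and amino would also read alike on the core of compound 1 remains open. So does the outcome at this place on the core of compound 3 for a carboxylic acid, a methoxy group or a longer chain carrying an amine.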